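Pyrrole, furan and phenyl arms on the cyanoacrylamide series

This account rests on a few compounds, and the source may have more. Where it says the series, first, only, none or still open, it means among the compounds named here.

Measured compounds:
compound 1 `N#C/C(=C\c1ccc[nH]1)C(=O)NCc1ccc(Cl)c(Cl)c1` — > 50000 nM in a functional assay on SMA cells (Homo sapiens) for inhibition, read by MTT assay, with a stated time of 72 h; on this read-out lower numbers stand for stronger inhibition of growth and higher numbers for weaker inhibition of growth
compound 2 `N#C/C(=C\c1ccco1)C(=O)NCc1ccc(Cl)c(Cl)c1` — 38000 nM
compound 3 `COc1ccc(CNC(=O)/C(C#N)=C/c2ccc(C)o2)cc1` — 69000 nM

Compound 1 gives only a limit in this assay, > 50000 nM, not a number. Compound 2 gives 38000 nM, and the step of an at least 1.3-fold lower number from compound 1 to compound 2 (0.11 log units; that floor lies within the scatter) stays within the scatter. Compound 3 gives 69000 nM, the highest of the two numbers shown; its gap to compound 2 is within the scatter, so no order between them is claimed. The one limit in the set is the limit of > 50000 nM in this assay, at which 1 of the 3 values shown sits.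

Compound 4 `COc1ccc(CNC(=O)/C(C#N)=C/c2ccc(C)cc2)cc1` is not yet measured. It differs from compound 3 by 4-methylphenyl in place of 5-methylfuran-2-yl on a double-bonded chain carbon bound to a double-bonded chain carbon. Going by the values given here, only one measured step concerns the group on that chain carbon, the change from compound 1 to compound 2, and it stayed within the scatter. Among the compounds with values here, no measured step exchanges a five-membered ring for a six-membered ring. The expectation for compound 4 is therefore a step of a 1.2-fold lower number from compound 3 to compound 4 (0.06 log units; within the scatter), nothing beyond the scatter. Compound 4 is estimated at 60000 nM, with a range from 20000 nM to 180000 nM, and a real chance that the assay reports only a limit.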

Compound 4, concentration for 50% growth inhibition: 42000 nM
The estimate for compound 4 lay 1.4-fold (0.15 log units) above the measured number, and the stated range covers the measured number.
By their numbers in this assay, from the lowest: compounds 2, 4 and 3 (each within the scatter of the next).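

In this assay, the exchange of 5-methylfuran-2-yl for 4-methylphenyl on the double-bonded chain carbon gives a 1.6-fold lower number from compound 3 to compound 4 (0.22 log units; within the scatter). Going by these compounds alone, this is the first measured exchange of a five-membered aromatic ring for a six-membered aromatic ring at this position, and it is also the first ring here of carbon only. With the hetero atom and its hydrogen-bond acceptor gone, compound 4 still gives a number rather than a limit, so for this pair neither is needed for a readable value.

Whether an amine or a carboxylic acid on the 4-methylphenyl ring, or a longer chain in place of its methyl, would give a step beyond the scatter remains open, as no step shown at this position clearly exceeds it. Compound 1 also remains a limit and not a number: the limit of > 50000 nM in this assay, at which 1 of the 4 values shown sits.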